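Amide to urea at the carbonyl of the series

The source may hold more compounds than are shown below. What is called first, only, known or untested is meant among the compounds shown, and "the series" means these compounds.

Measured so far:
compound 1 `O=C(c1ccc(F)cc1)N1CC(c2nc(-c3cccc(Cl)c3)no2)C1`: > 10000 nM
compound 2 `O=C(c1cccc(F)c1)N1CC(c2nc(-c3cccc(Cl)c3)no2)C1`: > 10000 nM
compound 3 `O=C(C1CCC(F)(F)CC1)N1CC(c2nc(-c3cccc(Cl)c3)no2)C1`: 180 nM

Among the compounds with values here, in an assay on HEK293 cells for positive allosteric modulation of metabotropic glutamate receptor 5 (Homo sapiens), read by FLIPR (on this read-out lower numbers stand for an effect already at smaller amounts and higher numbers for an effect only at larger amounts of compound), compound 3 gives 180 nM, the only number in the set. For compound 1 the value > 10000 nM is a limit of the assay. For compound 2 the value > 10000 nM is likewise a limit, two of the three values sitting there (the limit of > 10000 nM in this assay, at which 2 of the 3 values shown sit). Compound 4 `CC1CCN(C(=O)N2CC(c3nc(-c4cccc(Cl)c4)no3)C2)CC1` differs from compound 3 in that (4-methylpiperidin-1-yl in place of 4,4-difluorocyclohexyl on a carbonyl carbon). The measured steps that bear on a change at this carbonyl carbon are an at least 55-fold lower number from compound 1 to compound 3 (1.74 log units; beyond the scatter) and an at least 55-fold lower number from compound 2 to compound 3 (1.74 log units; beyond the scatter), both leading from a fluorophenyl to a saturated ring; the step that the two limits leave unreadable from compound 1 to compound 2 is unreadable. The change to compound 4 keeps a saturated six-membered ring but brings a ring nitrogen onto the carbonyl carbon, so the measured steps give only loose guidance. Compound 4 is expected to retain an effect at a somewhat higher number than compound 3, the expected step being a 3.3-fold higher number from compound 3 to compound 4 (0.52 log units; beyond the scatter). The estimate for compound 4 is 600 nM, within 120 nM to 6000 nM.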

Compound 4, half-maximal effective concentration: 865 nM
Estimate against measurement, compound 4: 1.4-fold (0.16 log units) below; low and high end bracket the measured number.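

In this assay, a measurable effect at this carbonyl carbon is no longer confined to the 4,4-difluorocyclohexyl group, and both saturated rings now stand apart from the fluorophenyl pair: an at least 11-fold lower number from compound 1 to compound 4 (1.06 log units; beyond the scatter) and an at least 11-fold lower number from compound 2 to compound 4 (1.06 log units; beyond the scatter). Both steps start from a value that is a limit of the assay, and the step between the two fluorophenyl compounds cannot be read: the limit of > 10000 nM in this assay, at which 2 of the 4 values shown sit. The exchange of saturated rings still moves the read-out, with a 4.8-fold higher number from compound 3 to compound 4 (0.68 log units; beyond the scatter), but the ring nitrogen, the methyl group and the loss of fluorine change together, so the step cannot be assigned to any one of them.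

A 4,4-difluoropiperidin-1-yl or 4-methylcyclohexyl group at this place would separate these changes. Going by these compounds, how morpholine or an open-chain dialkylamine on the same carbonyl carbon would read remains open.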